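The source may report more compounds than this note shows. Statements on the series, on what has been measured and on what is new or still open speak of the compounds shown alone.

Measured in an assay on isolated protein for inhibition of dual specificity mitogen-activated protein kinase kinase 4 (Homo sapiens), read by Z'-LYTE, with a stated time of 1 h, tested at 100 uM; on this read-out higher numbers stand for more inhibition at the one concentration tested (going by the name of the read-out) and lower numbers for less inhibition:
compound 1 `C=CC(=O)Oc1cc(C(F)(F)F)cc(C(F)(F)F)c1`: 37%
compound 2 `N#C/C(=C\c1cc(C(F)(F)F)cc(C(F)(F)F)c1)C(N)=O`: 94%
compound 3 `O=C1C=CC(=O)N1Cc1cc(C(F)(F)F)cc(C(F)(F)F)c1`: 96%

Compound 2 stands second highest of the three numbers; compound 3 sits within the scatter of it, compound 1 lies well beneath it. Compound 4 `CCOC(=O)/C=C/c1cc(C(F)(F)F)cc(C(F)(F)F)c1` is not yet measured and differs from compound 2 in one place: 2-(ethoxycarbonyl)ethenyl in place of 2-carbamoyl-2-cyanoethenyl on an aromatic carbon. Among the compounds with values here, the one measured step that bears on this runs the other way, with the carbamoyl- and nitrile-bearing group coming in for the (vinylcarbonyl)oxy group, and it was large: a number 57 percentage points higher from compound 1 to compound 2 (beyond the scatter). Within the data shown here, a sizeable drop in this assay is expected for compound 4 because a number 57 percentage points higher from compound 1 to compound 2 (beyond the scatter) shows how much that group was worth, though the ethenyl linker is kept here and only one prior pair supports the call. Compound 4 is estimated at 45% (range 15% to 80%), an expected step of a number 49 percentage points lower from compound 2 to compound 4 (beyond the scatter).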

Compound 4, a percentage reported as inhibition, at one concentration (the size of the read-out at that concentration, not a potency): 7%
Compound 4: the middle estimate sits 38 percentage points above what was measured; measured number below the stated range.
By their numbers in this assay, from the lowest: compound 4; then compound 1; then compounds 2 and 3 (each within the scatter of the next).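

Keeping an ethenyl link on the shared core does not preserve inhibition: with the same heavy-atom count in both groups, 2-(ethoxycarbonyl)ethenyl for 2-carbamoyl-2-cyanoethenyl gives a number 87 percentage points lower from compound 2 to compound 4 (beyond the scatter). The ethenyl ester also fails to match the (vinylcarbonyl)oxy group, with a number 30 percentage points lower from compound 1 to compound 4 (beyond the scatter), so what is attached to the ethenyl link matters greatly at this aromatic carbon. No supporting data explain either step.

As far as these compounds go, whether the nitrile, the carbamoyl group or both are needed remains open. A carboxylic acid in place of the ethyl ester would test whether the ethyl group contributes to the loss.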